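The source may report more compounds than this note shows. Statements on the series, on what has been measured and on what is new or still open speak of the compounds shown alone.

In a physicochemical assay for lipophilicity, read by HPLC, using the shake flask method (on this read-out lower numbers stand for lower lipophilicity and higher numbers for higher lipophilicity), compound 1 (`CCC/C(=N\C#N)N(C)Cc1ccc(Cl)nc1`) gives 1.55 and compound 2 (`CCCCN(Cc1ccc(Cl)nc1)/C(C)=N/C#N`) gives 2.13 on the same scale. Going by the values given here, compound 1 so holds the lower of the two numbers so far, and the gap between them lies beyond the scatter. Compound 3 (`CC(C)C/C(=N\C#N)N(C)Cc1ccc(Cl)nc1`) differs from compound 1 by methyl in place of hydrogen on a saturated chain carbon bound to two saturated chain carbons in one place: methyl in place of hydrogen on a saturated chain carbon bound to two saturated chain carbons, so propyl becomes isobutyl. Among the compounds with values here, no measured pair shows this change directly. An upward move is expected, with an estimated step of a number 0.40 log units higher from compound 1 to compound 3 (beyond the scatter) in this assay for this single added carbon. Compound 3 is estimated at 1.95 with an expected range from 1.65 to 2.25 in this measurement.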

Compound 3, partition coefficient: 1.75
Compound 3: middle estimate off by 0.20 log units, on the high side; measured number inside the range.
By their numbers in this assay, from the lowest: compounds 1 and 3 (each within the scatter of the next); then compound 2.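

In this assay, methyl in place of hydrogen on a saturated chain carbon bound to two saturated chain carbons, turning propyl into isobutyl, gives a number 0.20 log units higher from compound 1 to compound 3 (within the scatter) in this single pair. So this one added carbon, at this place on the core of compound 1, does not separate the two compounds on this read-out. No measurement offered here bears on why the step has this size. The compounds shown leave open what a longer chain, such as pentyl, or an amine at the same place would give, and whether the same change would read alike on another chain.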